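A Chlorophenyl Swap Tried on a Second Core

The source may hold more compounds than are shown below. What is called first, only, known or untested is meant among the compounds shown, and "the series" means these compounds.

The measured compounds:
Compound 1 `COc1ncc(-c2ccc3c(c2)NC(=O)CO3)cc1NS(=O)(=O)c1ccc(F)cc1` gives 24900 nM.
Compound 3 `COc1ncc(-c2ccc3c(c2)N(c2ccc(Cl)cc2)C(=O)CO3)cc1NS(=O)(=O)c1ccc(F)cc1` gives 19200 nM.
Compound 2 `O=C1COc2ccc(-c3cnc4ccccc4c3)cc2N1` gives > 40000 nM, which is a limit of the assay and not a number.

In a functional assay on HCT-116 cells (Homo sapiens) for antiproliferative activity, read by MTT assay, with a stated time of 72 h (on this read-out higher numbers stand for weaker inhibition and lower numbers for stronger inhibition), compound 1 and compound 3 share one core and differ in one place: 4-chlorophenyl in place of hydrogen on an amide-type nitrogen in a ring. The step is a 1.3-fold lower number from compound 1 to compound 3 (0.11 log units; within the scatter), so the two numbers sit within the scatter of each other, and the change left the read-out essentially where it was.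

Compound 2 has a different core; the difference between the two cores is not broken down here. For compound 2 only the limit of > 40000 nM in this assay, at which 1 of the 3 values shown sits, is known.

Compound 4 `O=C1COc2ccc(-c3cnc4ccccc4c3)cc2N1c1ccc(Cl)cc1` is built from compound 2 by the same change: 4-chlorophenyl in place of hydrogen on an amide-type nitrogen in a ring. The two places match word for word, so this is the same change carried onto the core of compound 2. Since the step from compound 1 to compound 3 was small, compound 4 is expected to stay near compound 2, with an estimated step that the limit leaves unreadable from compound 2 to compound 4, resting on a 1.3-fold lower number from compound 1 to compound 3 (0.11 log units; within the scatter). Because compound 2 gave only > 40000 nM, compound 4 is expected to sit near or beyond that limit as well, with an estimate of 45000 nM in this assay, between 20000 nM and 100000 nM.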

Compound 4, half-maximal inhibitory concentration: 36100 nM
For compound 4 the middle estimate is 1.2-fold (0.10 log units) above the measured one; low and high end bracket the measured number.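

Carried onto the core of compound 2, the swap of hydrogen for 4-chlorophenyl on the amide-type nitrogen gives, in this assay, an at least 1.1-fold lower number from compound 2 to compound 4 (0.04 log units; that floor lies within the scatter). Compound 2 stands at > 40000 nM, which is a limit of the assay and not a number, so this step is known only as a floor and its true size stays unread. Side by side, the two steps show that no step printed for this change on either core lies beyond the scatter, but they do not show that the change moves the read-out by the same amount on both cores, and the comparison can go no further than this: the same change on two cores in this assay, a 1.3-fold lower number (0.11 log units; within the scatter) from compound 1 to compound 3 and an at least 1.1-fold lower number (0.04 log units; that floor lies within the scatter) from compound 2 to compound 4; the limit leaves it open whether they differ.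

The compounds shown leave open how far compound 2 lies past its limit, and with it how large the step on that core really is. They also leave open whether a group other than 4-chlorophenyl on the same nitrogen, such as a methyl group, a longer chain, an amine or a carboxylic acid, would shift the read-out on either core by more than the scatter.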